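This account rests on a few compounds, and the source may have more. Where it says the series, first, only, none or still open, it means among the compounds named here.

Working notes on the series, read in a functional assay on MV4-11 cells (Homo sapiens) for antiproliferative activity, read by CellTiter-Glo, with a stated time of 72 h; a higher number here means a weaker inhibitor of growth, a lower number a stronger inhibitor of growth. Compound 1 `Fc1cc(-c2csc(NCC3CCOCC3)n2)c(Cl)cn1` gives > 10000 nM, which is a limit of the assay and not a number. Compound 2 `Clc1cnc(Nc2ccccc2)cc1-c1csc(NCC2CCOCC2)n1` gives > 10000 nM, again only a limit. For the measured compounds named here, compound 3 `O=C(Nc1cc(-c2csc(NCC3CCOCC3)n2)c(Cl)cn1)c1ccc(F)cc1` gives 550 nM, the only true number so far.

The next step leads to compound 4 `N[C@H]1CC[C@H](Nc2cc(-c3csc(NCC4CCOCC4)n3)c(Cl)cn2)CC1`. The change from compound 3 is 4-aminocyclohexyl in place of (4-fluorophenyl)carbonyl on a nitrogen on an aromatic ring. In short, 4-aminocyclohexyl replaces (4-fluorophenyl)carbonyl on a nitrogen on an aromatic ring.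

Going by the values given here, three measured steps bear on this place. Two are large and beyond the scatter: an at least 18-fold lower number from compound 1 to compound 3 (1.25 log units; beyond the scatter) and an at least 18-fold lower number from compound 2 to compound 3 (1.25 log units; beyond the scatter). The third, a step that the two limits leave unreadable from compound 1 to compound 2, gives no readable size. Among the compounds with values here, no measured compound yet carries a non-aromatic ring on this nitrogen, so the direction rests on thin ground. With the group on this nitrogen already worth an at least 18-fold lower number from compound 2 to compound 3 (1.25 log units; beyond the scatter), a further step beyond the scatter is expected in this assay, more likely towards a lower number than a higher one. The estimated move is a 5.5-fold lower number from compound 3 to compound 4 (0.74 log units; beyond the scatter). For compound 4 the expected value is 100 nM, within an estimated range of 15 nM to 700 nM.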

Compound 4, concentration for 50% growth inhibition: 140 nM
Compound 4: middle estimate off by 1.4-fold (0.15 log units), on the low side; low and high end bracket the measured number.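

In this assay, a carbonyl on this nitrogen is not needed for a low number: 4-aminocyclohexyl, with a non-aromatic ring and an amine, takes the place of (4-fluorophenyl)carbonyl and gives a 3.9-fold lower number from compound 3 to compound 4 (0.59 log units; beyond the scatter). Set against phenyl on the same nitrogen, it gives an at least 71-fold lower number from compound 2 to compound 4 (1.85 log units; beyond the scatter), and set against fluoro on the aromatic carbon, the whole (4-aminocyclohexyl)amino group gives an at least 71-fold lower number from compound 1 to compound 4 (1.85 log units; beyond the scatter), so among the compounds shown, neither an aromatic ring nor a carbonyl on this nitrogen is required. Both of these larger sizes are floors resting on a limit of the assay and not on a number: the limit of > 10000 nM in this assay, at which 2 of the 4 values shown sit.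

Going by these compounds, what a plain cyclohexyl without the amine would give on this nitrogen stays open, so the step cannot yet be divided between the amine and the non-aromatic ring. Also open, on these data alone, are the other arrangement of the two defined stereocentres and whether a hydroxyl or an aminomethyl group in place of the amine would hold the number in this assay.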